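Replacing the imidazolyl group on the hydrazone aryl ring

The source may hold more compounds than are shown below. What is called first, only, known or untested is meant among the compounds shown, and "the series" means these compounds.

The series shares a core carrying a hydrazone-linked aryl ring whose substituent is varied. In an assay on CHO-K1 cells for displacement of a labelled ligand from adenosine receptor A1 (Homo sapiens), read by scintillation counting, with a stated time of 60 min (a lower number here means a stronger inhibitor, a higher number a weaker inhibitor), compound 1 `Nc1nc(N/N=C/c2ccc(N3CCCC3)cc2)nc2c1ncn2[C@@H]1O[C@H](CO)[C@@H](O)[C@H]1O` gives 5.1 nM, compound 2 `Nc1nc(N/N=C/c2ccc(-c3ccccn3)cc2)nc2c1ncn2[C@@H]1O[C@H](CO)[C@@H](O)[C@H]1O` gives 7540 nM, and compound 3 `Nc1nc(N/N=C/c2ccc(-n3ccnc3)cc2)nc2c1ncn2[C@@H]1O[C@H](CO)[C@@H](O)[C@H]1O` reaches only the limit of this assay, > 10000 nM (the limit of > 10000 nM in this assay, at which 1 of the 3 values shown sits). Compound 3 thus stands at the weak end of what has been measured, with no number of its own. The two steps away from compound 1 were large: a 1500-fold higher number from compound 1 to compound 2 (3.17 log units; beyond the scatter) and an at least 1900-fold higher number from compound 1 to compound 3 (3.29 log units; beyond the scatter); between the two heteroaryl analogues, an at least 1.3-fold higher number from compound 2 to compound 3 (0.12 log units; that floor lies within the scatter).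

Compound 4 `Nc1nc(N/N=C/c2ccc(OCc3ccc(F)cc3)cc2)nc2c1ncn2[C@@H]1O[C@H](CO)[C@@H](O)[C@H]1O` differs from compound 3 as follows: (4-fluorobenzyl)oxy in place of 1H-imidazol-1-yl on an aromatic carbon. No measured step involves a benzyloxy-type group, so the listed steps bear on it only indirectly: they show that the pyrrolidinyl of compound 1 is the sole substituent giving a low number, and that both aromatic replacements lost heavily. The expectation for compound 4 is therefore broad: a number somewhat lower than the limit of compound 3 is estimated, an at least 5.0-fold lower number from compound 3 to compound 4 (0.69 log units; beyond the scatter), giving an estimated 2000 nM with a range from 150 nM to 10000 nM, and a fair chance that only a limit is again reported.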

Compound 4, inhibition constant: 70 nM
The estimate for compound 4 lay 29-fold (1.46 log units) above the measured number, and the stated range ends above it.
By their numbers in this assay, from the lowest: compound 1; then compound 4; then compound 2. At a limit, above all of these: compound 3.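

In this assay, a low number at this position is no longer confined to the pyrrolidin-1-yl of compound 1: (4-fluorobenzyl)oxy in place of pyridin-2-yl gives a 110-fold lower number from compound 2 to compound 4 (2.03 log units; beyond the scatter). In place of 1H-imidazol-1-yl, the same group gives an at least 140-fold lower number from compound 3 to compound 4 (2.15 log units; beyond the scatter), a step that starts from a limit and not from a number: the limit of > 10000 nM in this assay, at which 1 of the 4 values shown sits. The pyrrolidin-1-yl group still holds the lowest number of the set, with a 14-fold higher number from compound 1 to compound 4 (1.14 log units; beyond the scatter), so (4-fluorobenzyl)oxy recovers much, but not all, of the loss seen with the two heteroaryl groups.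

The compounds shown do not separate the contributions of the oxygen, the benzyl ring and the fluorine in compound 4. An unsubstituted benzyloxy, a methoxy or a dimethylamino group at this position would help to separate them.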